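The source may report more compounds than this note shows. Statements on the series, on what has been measured and on what is new or still open speak of the compounds shown alone.

The series rests on a shared core, seen in compound 1 `CNC(=O)c1cc(Oc2ccc3nc(NC(=O)Nc4ccc(N5CCN(C)CC5)cc4)sc3c2)ccn1` and compound 2 `CNC(=O)c1cc(Oc2ccc3nc(NC(=O)Nc4ccc(Br)cc4)sc3c2)ccn1`. In a functional assay on HCT-116 cells (Homo sapiens) for inhibition, read by MTT assay, with a stated time of 2 days, tested at 10 uM (a lower number here means less inhibition of growth, a higher number more inhibition of growth at the concentration tested), compound 1 gives 24.6%, and in this assay compound 2 gives 12.1%. The one step that connects them, a number 12.5 percentage points lower from compound 1 to compound 2 (beyond the scatter), leaves compound 2 with the lower of the two numbers shown, the only neighbour being compound 1.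

The next compound, compound 3 `CNC(=O)c1cc(Oc2ccc3nc(NC(=O)Nc4ccc(F)cc4)sc3c2)ccn1`, differs from compound 2 in one place: fluoro in place of bromo on an aromatic carbon. Among the measured compounds shown here, no measured step swaps one halogen for another, so the only guide is the single step from compound 1 to compound 2, which was modest and came with a far larger change of group. A swap of bromo for fluoro at the same position is expected to move the number less than that, if at all, and no direction can be set on the evidence at hand. Compound 3 is therefore estimated to sit close to compound 2, at 11% in this assay, within a range of -5% to 28%, the expected step being a number 1.1 percentage points lower from compound 2 to compound 3 (within the scatter).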

Compound 3, percent growth inhibition at one concentration: 12.2%
Estimate against measurement, compound 3: 1.2 percentage points below; the measured number falls inside the stated range.
By their numbers in this assay, from the lowest: compounds 2 and 3 (each within the scatter of the next); then compound 1.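

In this assay, the change from bromo to fluoro on an aromatic carbon para to a large group gives a number 0.1 percentage points higher from compound 2 to compound 3 (within the scatter), so the two halogens cannot be told apart at this position. The other new step, a number 12.4 percentage points lower from compound 1 to compound 3 (beyond the scatter), lies beyond the scatter, as does a number 12.5 percentage points lower from compound 1 to compound 2 (beyond the scatter), which shows that the higher number of compound 1 stands against both halogens and not against bromo alone. The information at hand gives no reason for either result.

Going by these compounds, only one kind of replacement for the 4-methylpiperazin-1-yl group is covered here, so it remains open whether the higher number depends on the whole ring, on its methyl group or simply on having an amine at this position; piperazine without the methyl group, morpholine and dimethylamino would each bear on this. On these data alone, it is also open how a carboxylic acid or a methoxy group would read here, and whether the small separation seen at a single concentration would hold across a range of concentrations.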